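The source may hold more compounds than are shown below. What is called first, only, known or untested is meant among the compounds shown, and "the series" means these compounds.

Compound 1 `CCCCCCCCNC(=O)[C@@H]1CSC(c2cc(OC)c(OC)c(OC)c2)N1` and compound 2 `CCCCCCCCCCCCNC(=O)[C@@H]1CSC(c2cc(OC)c(OC)c(OC)c2)N1` share a core and differ only in the saturated chain on the amide-type nitrogen. In a functional assay on WM164 cells (Homo sapiens) for antiproliferative activity, read by sulforhodamine B assay, with a stated time of 48 h (a lower number here means a stronger inhibitor, a higher number a weaker inhibitor), compound 1 gives 19600 nM and compound 2 gives 2400 nM as its number, so compound 2 holds the lower of the two values and is the stronger inhibitor of this pair. Compound 3 `CCCCCCCCCCCCCCNC(=O)[C@@H]1CSC(c2cc(OC)c(OC)c(OC)c2)N1` has not yet been measured. It extends the chain further (ethyl in place of hydrogen on a saturated chain carbon, ten or more bonds along the chain from an amide-type nitrogen), with ethyl in place of hydrogen on a saturated chain carbon, ten or more bonds along the chain from an amide-type nitrogen. Within the data shown here, only one measured step bears on this change. Butyl in place of hydrogen on the chain gave an 8.2-fold lower number from compound 1 to compound 2 (0.91 log units; beyond the scatter) as a modest move beyond the scatter. Ethyl is a smaller addition than butyl, and one step cannot show whether the trend carries on, so a smaller move in the same direction is expected. The step expected here is a 2.2-fold lower number from compound 2 to compound 3 (0.34 log units; beyond the scatter) as an estimate, toward a lower number. Compound 3 is estimated at 1100 nM with an expected range of 450 nM to 3000 nM around that middle value.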

Compound 3, half-maximal inhibitory concentration: 1600 nM
Estimate against measurement, compound 3: 1.5-fold (0.16 log units) below; the measured number falls inside the stated range.
By their numbers in this assay, from the lowest: compounds 3 and 2 (each within the scatter of the next); then compound 1.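

In this assay the ethyl placed on a saturated chain carbon gives a 1.5-fold lower number from compound 2 to compound 3 (0.18 log units; within the scatter) and so leaves compound 2 and compound 3 indistinguishable, unlike the earlier butyl step, which lay beyond the scatter. Across the whole stretch of chain, hexyl in place of hydrogen still gives a 12-fold lower number from compound 1 to compound 3 (1.09 log units; beyond the scatter) and so separates compound 3 clearly from compound 1, which means that the clear difference among these three compounds lies between compound 1 and the other two. Nothing measured here offers an explanation for this result.

Among these compounds, still open is whether a longer chain than the one in compound 3 would leave the number unchanged or move it up or down. Also open is what would happen if a carboxylic acid or an amine stood at the far end of the chain, as all three compounds shown carry a plain saturated chain there.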